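The source may report more compounds than this note shows. Statements on the series, on what has been measured and on what is new or still open speak of the compounds shown alone.

Measured compounds in an ADME assay on MT4 cells (Homo sapiens) for cytotoxicity, with a stated time of 5 days; on this read-out lower numbers stand for higher toxicity in this test and higher numbers for lower toxicity in this test:

Compound 1 `CC(C)(C)C#Cc1cc(N(C(=O)[C@H]2CC[C@H](C)CC2)[C@H]2CC[C@@](O)(CO[C@H]3CCOC3)CC2)c(C(=O)O)s1` gives > 20000 nM, a limit of the assay rather than a number.
Compound 2 `CC(C)(C)C#Cc1cc(N(C(=O)[C@H]2CC[C@H](C)CC2)[C@H]2CC[C@](O)(CO[C@H]3CCOC3)CC2)c(C(=O)O)s1` gives > 20000 nM, again a limit and not a number.
Compound 3 `CC(C)N(C(=O)[C@H]1CC[C@@H]2C[C@@H]2CC1)c1cc(C#CC(C)(C)C)sc1C(=O)O` gives > 20000 nM, also a limit.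

Compound 2 therefore stands only at a limit in this assay; none of the three compounds shows a number, and all sit at the same point, (the limit of > 20000 nM in this assay, at which 3 of the 3 values shown sit). Going by the values given here, the single step that can be traced, a step that the two limits leave unreadable from compound 1 to compound 2, cannot be read in size or direction because the limit of > 20000 nM in this assay, at which 3 of the 3 values shown sit, hides both ends, although the fact that compounds 1 and 2 differ only in the configuration as drawn shows the two compounds to be the same in atoms and bonds.

The move to compound 4 `CC(C)(C)C#Cc1cc(N(C(=O)[C@H]2CC[C@H](C)CC2)[C@H]2CC[C@H](O)CC2)c(C(=O)O)s1` is a different kind of change: hydrogen in place of ((oxolan-3-yl)oxy)methyl on a saturated ring carbon. Among the compounds with values here, no measured step bears on this change, so there is no measured size to lean on, and the one step available is unreadable in any case. Given that compounds 1, 2 and 3 all rest at the limit, compound 4 is expected to behave no differently, and the step that the limit leaves unreadable from compound 2 to compound 4 is estimated to be nothing beyond the scatter. Compound 4 is thus expected to give about 25000 nM in this assay, within a range from 10000 nM to 60000 nM, most likely reported again only as a limit.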

Compound 4, half-maximal cytotoxic concentration: > 20000 nM
Compound 4: only a limit was reported; the forecaster's own chance of this, stated with the estimate: 85%; the middle value is on the limit's open side.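

In this assay compound 4 gives > 20000 nM as a limit and not a number. The step from compound 2 to compound 4, hydrogen in place of ((oxolan-3-yl)oxy)methyl, therefore cannot be read in size or direction: the limit of > 20000 nM in this assay, at which 4 of the 4 values shown sit.

The compounds shown leave open whether this change, or the difference in configuration between compound 1 and compound 2, alters cytotoxicity at all.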